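A few compounds are considered here, and "the series" means these few. Any claim that something is new, unique, unknown or untested is made for them only; others in the source may bear on it.

Measured so far in an assay for displacement of a labelled ligand from Sigma non-opioid intracellular receptor 1 (Cavia porcellus); on this read-out lower numbers stand for stronger inhibition and higher numbers for weaker inhibition:

Compound 1, `O=C(NC1CCCCC1)C1CCN(Cc2ccc(Cl)cc2)CC1`: 7.7 nM
Compound 2, `O=C(C1CCN(Cc2ccccc2)CC1)N1CCc2ccccc2C1`: 8.8 nM
Compound 3, `O=C(NC1CCCCC1)C1CCN(Cc2ccc(Cl)cc2Cl)CC1`: 52 nM

Compound 1 and compound 3 share a core and differ by chloro in place of hydrogen on an aromatic carbon. That step, a 6.8-fold higher number from compound 1 to compound 3 (0.83 log units; beyond the scatter), runs beyond the scatter. Compound 2 and compound 1 have values within the scatter of each other; the difference between their two cores is not broken down here. Against compound 3, compound 2 stands at the lower number, the gap being beyond the scatter.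

Compound 4, `O=C(C1CCN(Cc2ccc(Cl)cc2)CC1)N1CCc2ccccc2C1`, is not yet measured in this assay. It differs from compound 2 by chloro in place of hydrogen on an aromatic carbon. Among the compounds with values here, this is the same kind of change as the one from compound 1 to compound 3, but not the same: there the entering chloro sits ortho to a large group and meta to a chloro group, whereas in compound 4 it sits para to a large group, on a ring that carries no other chloro.

For compound 4 in this assay the expected step is a 1.3-fold lower number from compound 2 to compound 4 (0.10 log units; within the scatter), smaller than the step from compound 1 to compound 3. This rests on compound 1, which carries a 4-chlorobenzyl on its own core and gives 7.7 nM, a number within the scatter of compound 2. The estimate for compound 4 is 7 nM, expected between 2.5 nM and 20 nM.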

Compound 4, inhibition constant: 8 nM
The estimate for compound 4 lay 1.1-fold (0.06 log units) below the measured number; measured number inside the range.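

In this assay, chloro in place of hydrogen on an aromatic carbon does not carry from one core to the other as a fixed step: the same change on two cores in this assay, a 6.8-fold higher number (0.83 log units; beyond the scatter) from compound 1 to compound 3 and a 1.1-fold lower number (0.04 log units; within the scatter) from compound 2 to compound 4, 7.4-fold (0.87 log units) apart, beyond the scatter of two such steps

Taken alone, the new step, a 1.1-fold lower number from compound 2 to compound 4 (0.04 log units; within the scatter), shows that benzyl to 4-chlorobenzyl leaves no readable difference on the core of compound 2. This does not show that the core alone sets the outcome, since the two steps also differ in where the chloro enters: in compound 4 it sits para to a large group on a ring that carries no other chloro, whereas in compound 3 it enters a ring that already carries one, and with one step on each core the two differences cannot be told apart.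

The compounds shown leave open whether a second chloro placed on the ring of compound 4 as in compound 3 would repeat the earlier step on this core, and how the plain benzyl behaves on the core of compound 1. They also leave open whether a fluoro or a methoxy group in the place of the chloro of compound 4 would stay as close to compound 2 as the chloro does.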